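Furan for methoxyphenyl on a nitrooxy amide chalcone

The source may hold more compounds than are shown below. What is called first, only, known or untested is meant among the compounds shown, and "the series" means these compounds.

Four related compounds are considered here, all built around an amide-bearing chalcone core. Compound 1 is `COc1ccc(/C=C/C(=O)c2ccc(NC(=O)C(C)Br)cc2)cc1`, compound 2 is `CC(Br)C(=O)Nc1ccc(C(=O)/C=C/c2ccco2)cc1`, compound 3 is `COc1ccc(/C=C/C(=O)c2ccc(NC(=O)C(C)O[N+](=O)[O-])cc2)cc1`, and compound 4, which has not yet been measured, is `CC(O[N+](=O)[O-])C(=O)Nc1ccc(C(=O)/C=C/c2ccco2)cc1`.

The measurements come from a functional assay on the whole organism (strain albino) for inhibition, with Rattus norvegicus as the target, read by paw edema, with stated times of 30 min and 5 h, at a dose of 100 mg/kg by the oral route; on this read-out lower numbers stand for less inhibition and higher numbers for more inhibition at the one dose given (going by the name of the read-out). In this assay compound 1 gives 31%, compound 2 gives 34%, and compound 3 gives 35%. All three numbers sit close together, and none of the steps between them leaves the usual scatter.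

Compound 1 and compound 3 share the same right-hand part and differ only in the side chain: nitrooxy in place of bromo on a saturated chain carbon bound to a carbonyl carbon and a saturated chain carbon. The step that goes with this difference is a number 4 percentage points higher from compound 1 to compound 3 (within the scatter).

Compound 2 arises from compound 1 by a single swap at the far end of the double bond: furan-2-yl in place of 4-methoxyphenyl on a double-bonded chain carbon bound to a double-bonded chain carbon. This gave a number 3 percentage points higher from compound 1 to compound 2 (within the scatter). Compound 4 arises from compound 3 by exactly the same swap at the same place: furan-2-yl in place of 4-methoxyphenyl on a double-bonded chain carbon bound to a double-bonded chain carbon. This change occurs twice among the four compounds, once measured and once not.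

Because a number 3 percentage points higher from compound 1 to compound 2 (within the scatter), the same swap on the nitrooxy core is expected to move the number by a similar small amount, so the step to compound 4 is estimated as a number 3 percentage points higher from compound 3 to compound 4 (within the scatter). Compound 4 is therefore expected to give about 38%, most likely between 26% and 50%, resting on compound 3 at 35%.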

Compound 4, a percentage reported as inhibition, in the whole organism at one dose (the size of the read-out at that dose, not a potency): 49%
Compound 4: the middle estimate sits 11 percentage points below what was measured, and the stated range covers the measured number.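

In this assay, furan-2-yl in place of 4-methoxyphenyl on the nitrooxy core gave a number 14 percentage points higher from compound 3 to compound 4 (beyond the scatter), a larger step than the one on the bromo core, but the two steps cannot be told apart: the same change on two cores in this assay, a number 3 percentage points higher (within the scatter) from compound 1 to compound 2 and a number 14 percentage points higher (beyond the scatter) from compound 3 to compound 4, 11 percentage points apart, within the scatter of two such steps. The other change reads the same way, with nitrooxy in place of bromo on the furan-bearing core giving a number 15 percentage points higher from compound 2 to compound 4 (beyond the scatter), again a larger step than on the core of compound 1 but not separable from it: the same change on two cores in this assay, a number 4 percentage points higher (within the scatter) from compound 1 to compound 3 and a number 15 percentage points higher (beyond the scatter) from compound 2 to compound 4, 11 percentage points apart, within the scatter of two such steps. This shows that neither change has been found to behave differently on the two cores, so carrying each from one core to the other remains reasonable within these four compounds, but it does not show that the two changes simply add up, as each comparison rests on just one pair of single steps.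

The compounds shown leave open whether the higher number of compound 4 would hold with another group in place of furan-2-yl, such as an amine or a carboxylic acid, or with a longer chain carrying the nitrooxy. They also leave open how these compounds compare at other doses, as every number here comes from a single dose.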